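A few compounds are considered here, and "the series" means these few. Any claim that something is new, unique, unknown or untested is made for them only; others in the source may bear on it.

Compound 1, `Cc1c(C(=O)Nc2ccc(-c3ccccc3)cc2)nc2ccccc2c1O`: 4.56%
Compound 2, `COc1ccc2nc(C(=O)Nc3ccc(-c4ccccc4)cc3)c(C)c(C(=O)O)c2c1`: 21.3%

Both compounds were tested in a functional assay on A-375 cells (Homo sapiens) for antiproliferative activity, read by MTT assay, with a stated time of 24 h, tested at 1.23 ug/mL; a higher number here means a stronger effect of the compound at the concentration tested, a lower number a weaker effect. Compound 2 stands highest of the two numbers there, and its nearest neighbour is compound 1, whose value is lower by a gap beyond the usual scatter of such measurements. No single structural change connects these two compounds, so nothing more can be drawn from the pair than what the two values show.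

Compound 3, `Cc1c(C(=O)Nc2ccc(-c3ccccc3)cc2)nc2ccccc2c1C(=O)O`, has not yet been measured in this assay. It differs from compound 2 in one place: hydrogen in place of methoxy on an aromatic carbon. Within the data shown here, no step between measured compounds isolates this change, so its effect cannot be read off from the data at hand. The expectation rests on compound 2 alone, whose value is 21.3%, with compound 1 giving only a distant point of comparison. The step from compound 2 to compound 3 is expected to be small and downward, roughly a number 6.3 percentage points lower from compound 2 to compound 3 (within the scatter), and may well lie within the scatter. Compound 3 is therefore estimated at 15%, within a range of 3% to 30%.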

Compound 3, a percentage reported as inhibition, at one concentration (the size of the read-out at that concentration, not a potency): 7.65%
Estimate against measurement, compound 3: 7.4 percentage points above; the measured number falls inside the stated range.
By their numbers in this assay, from the lowest: compounds 1 and 3 (each within the scatter of the next); then compound 2.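

In this assay, among these compounds, putting hydrogen in place of methoxy on the aromatic carbon gives a number 13.7 percentage points lower from compound 2 to compound 3 (beyond the scatter), the first single-place comparison in this set, and it shows that what sits at this position matters at the concentration tested: compound 2, which carries the methoxy, gives the larger read-out. A second single-place comparison concerns a different spot on the core, where carboxy in place of hydroxy on an aromatic carbon gives a number 3.1 percentage points higher from compound 1 to compound 3 (within the scatter), so compound 1 and compound 3 cannot be told apart here, and this swap shows no clear effect on the read-out when the methoxy is absent. Nothing measured here explains why the methoxy step comes out as it does.

As far as these compounds go, it remains open whether the larger read-out is tied to methoxy itself or would also appear with another group at this position, such as ethoxy, a fluorine atom or an amine. Also open, from the compounds shown here alone, is what hydroxy in place of carboxy would do on a core that keeps the methoxy, and, since each compound was read at one concentration only, whether the stronger effect of compound 2 at that concentration would hold at other concentrations.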